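The source may report more compounds than this note shows. Statements on the series, on what has been measured and on what is new or still open speak of the compounds shown alone.

Compounds measured so far in a functional assay on KB cells (Homo sapiens) for inhibition, read by sulforhodamine B assay, with a stated time of 72 h; a lower number here means a stronger inhibitor of growth, a higher number a weaker inhibitor of growth:

compound 1 `COC1CN(C(=O)/C=C/c2ccncc2-c2ccc3ccccc3c2)C1`: > 10000 nM.
compound 2 `O=C(O)CCc1ccncc1-c1ccc2ccccc2c1`: > 10000 nM.

The result of compound 1 is a limit of the assay rather than a number: compound 1 gives > 10000 nM. The result of compound 2 is likewise a limit: compound 2 gives > 10000 nM. Compound 2 therefore stands at the limit itself, where both of the two values sit (the limit of > 10000 nM in this assay, at which 2 of the 2 values shown sit), and nothing in the numbers places one of these compounds above the other.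

Compound 3 `COC(=O)/C=C/c1ccncc1-c1ccc2ccccc2c1` has not yet been measured in this assay. It differs from compound 2 in one place: 2-(methoxycarbonyl)ethenyl in place of 2-carboxyethyl on an aromatic carbon. Among the compounds with values here, no step between measured compounds exists here to show what such a change does to growth inhibition. With both measured compounds at the limit, the step of a number no higher from compound 2 to compound 3 (the limit leaves the size open) is expected to be none beyond the scatter, although a gain cannot be excluded. Compound 3 is estimated at 10000 nM, with a range from 2000 nM to 30000 nM.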

Compound 3, concentration for 50% growth inhibition: 6730 nM
Compound 3: the middle estimate sits 1.5-fold (0.17 log units) above what was measured; measured number inside the range.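

In this assay compound 3 is the first compound shown to give a number rather than a limit, 6730 nM. On the aromatic carbon opposite the ring nitrogen, the change to 2-(methoxycarbonyl)ethenyl gives an at least 1.4-fold lower number from compound 2 to compound 3 (0.17 log units; that floor lies within the scatter), and on the carbonyl carbon, methoxy in place of 3-methoxyazetidin-1-yl gives an at least 1.4-fold lower number from compound 1 to compound 3 (0.17 log units; that floor lies within the scatter). The true size of both steps stays unknown, and either could go beyond the scatter, because each starts from a limit: the limit of > 10000 nM in this assay, at which 2 of the 3 values shown sit.

The change from compound 2 adds a double bond and replaces the free acid with a methyl ester at once, and only 2-(methoxycarbonyl)ethyl or 2-carboxyethenyl, each carrying one of these changes, could separate the two. From the compounds shown here alone, how a primary amide or an amine on the same chain would behave also remains open.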